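From 4-methoxybenzyl to methyl in compound 2

The compounds below may be only part of what the source reports. "The series", "measured", "known", "first", "only" and "open" are said of these compounds alone.

- Compound 1 `Cn1nc(-c2ccccc2)c2cc(C(=N)Nc3ccccc3)ncc21`: 11100 nM
- Compound 2 `COc1ccc(Cn2ncc3cc(C(=N)Nc4ccccc4)ncc32)cc1`: 34700 nM

In a functional assay on MDA-MB-231 cells (Homo sapiens) for cytotoxicity, read by MTT assay, with a stated time of 72 h (a lower number here means a stronger inhibitor, a higher number a weaker inhibitor), compound 2 has the higher of the two numbers, which makes it the weaker inhibitor, and its gap to compound 1 lies beyond the scatter. Compound 3 `Cn1ncc2cc(C(=N)Nc3ccccc3)ncc21` has not been measured yet. It differs from compound 2 in one place: hydrogen in place of 4-methoxyphenyl on a saturated chain carbon bound to an aromatic nitrogen. In words, this is hydrogen in place of 4-methoxyphenyl on a saturated chain carbon bound to an aromatic nitrogen, so 4-methoxybenzyl becomes methyl.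

Going by the values given here, no measured pair shows this change alone, so the expectation is loose. Among the compounds with values here, the only guide is compound 1, which also carries methyl and gives 11100 nM, although it differs from compound 3 elsewhere. A small drift to a lower number is expected, a 1.6-fold lower number from compound 2 to compound 3 (0.20 log units; within the scatter), with no step beyond the scatter. For compound 3 the estimated value is 22000 nM, with an expected range from 8000 nM to 60000 nM.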

Compound 3, half-maximal inhibitory concentration: > 50000 nM
Compound 3: a limit, no number; the forecaster's own chance of this, stated with the estimate: 20%; middle value at least 2.2-fold (0.35 log units) away from the limit.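

In this assay the value of compound 3 is a limit and not a number: the limit of > 50000 nM in this assay, at which 1 of the 3 values shown sits. Cutting 4-methoxybenzyl down to methyl gives an at least 1.4-fold higher number from compound 2 to compound 3 (0.15 log units; that floor lies within the scatter), so the smaller group brings no measurable gain, although that floor alone does not establish a real loss. Going by these compounds alone, compound 3 also provides the first one-place comparison for the phenyl on the aromatic carbon: with hydrogen in its place, the result is an at least 4.5-fold higher number from compound 1 to compound 3 (0.65 log units; beyond the scatter), so within this pair the phenyl goes with the stronger inhibitor.

With compound 3 at a limit, the true size of both steps cannot be read. The compounds shown leave open whether plain benzyl in place of 4-methoxybenzyl, or an amine in place of the phenyl on the aromatic carbon, would give a stronger or weaker inhibitor.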